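Methylation of the phenol in a pyrazole urea series

This account rests on a few compounds, and the source may have more. Where it says the series, first, only, none or still open, it means among the compounds named here.

Measured so far in a functional assay on PC-3 cells (Homo sapiens) for inhibition, read by sulforhodamine B assay, with a stated time of 48 h, tested at 0.1 uM; a lower number here means a stronger effect, a higher number a weaker effect of the compound at the concentration tested:
compound 1 `O=C(Nc1cccc(-n2cc(-c3ccncc3)c(-c3cc(O)cc(Cl)c3)n2)c1)Nc1ccc(Cl)c(C(F)(F)F)c1`: 98%
compound 2 `O=C(Nc1cccc(-n2cc(-c3ccncc3)c(-c3cc(O)cc(Cl)c3)n2)c1)Nc1ccc(Cl)c(Cl)c1`: 90%

Going by the values given here, on these numbers compound 1 and compound 2 lie within the scatter of each other; the one measured step, a number 8 percentage points lower from compound 1 to compound 2 (within the scatter), concerns the aryl urea end, not the phenol. Compound 3 `COc1cc(Cl)cc(-c2nn(-c3cccc(NC(=O)Nc4ccc(Cl)c(C(F)(F)F)c4)c3)cc2-c2ccncc2)c1` differs from compound 1 only by methyl in place of hydrogen on an oxygen on an aromatic ring. Among the compounds with values here, no measured step touches that position, so nothing in the data argues for a shift beyond the scatter. Compound 3 is therefore expected to give 94% (80% to 105%), a step of a number 4 percentage points lower from compound 1 to compound 3 (within the scatter), pending measurement.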

Compound 3, a percentage reported as activity, at one concentration (the size of the read-out at that concentration, not a potency): 91%
The estimate for compound 3 lay 3 percentage points above the measured number; the range from low to high includes it.
By their numbers in this assay, from the lowest: compounds 2, 3 and 1 (each within the scatter of the next).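

Hydroxy to methoxy gives the first measured step at this position: in this assay the change reads as a number 7 percentage points lower from compound 1 to compound 3 (within the scatter). At this single concentration, the read-out does not separate the 3-chloro-5-hydroxyphenyl compound from its 3-chloro-5-methoxyphenyl counterpart. No measured evidence bears on the reason for this result.

Still open, going by these compounds, is whether a longer chain on the oxygen, such as ethoxy, or an amine in place of the hydroxy would move the number beyond the scatter. Also open, on these data alone, is whether methoxy behaves alike with the dichlorophenyl urea of compound 2.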